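A few compounds are considered here, and "the series" means these few. Any claim that something is new, unique, unknown or untested is made for them only; others in the source may bear on it.

Measured so far:
compound 1 `CC(=O)c1ccc(OCc2cccc(C)c2)cc1`: 86.3 nM
compound 2 `CC(=O)c1ccc(OCc2ccc(Cl)cc2)cc1`: 63.2 nM

In an assay on isolated protein for inhibition of Amine oxidase [flavin-containing] B (Homo sapiens), read by Amplex Red, with a stated time of 15 min (a higher number here means a weaker inhibitor, a lower number a stronger inhibitor), compound 1 gives 86.3 nM, the higher of the two numbers; compound 2 gives 63.2 nM, and the two lie within the scatter of each other, so no order between them can be read. Compound 3 `CC(=O)c1ccc(OCc2cccc(C(F)(F)F)c2)cc1` has not been measured. It differs from compound 1 by trifluoromethyl in place of methyl on an aromatic carbon. Among the compounds with values here, no measured pair shows this exchange, so its size is unknown here; the expected step of a 1.1-fold lower number from compound 1 to compound 3 (0.03 log units; within the scatter) is taken as no change beyond the scatter, in no fixed direction. Compound 3 is thus expected at 80 nM in this assay, with a range from 35 nM to 200 nM.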

Compound 3, half-maximal inhibitory concentration: 58.2 nM
For compound 3 the middle estimate is 1.4-fold (0.14 log units) above the measured one; the measured number falls inside the stated range.
By their numbers in this assay, from the lowest: compounds 3, 2 and 1 (each within the scatter of the next).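

In this assay the exchange of methyl for trifluoromethyl on an aromatic carbon, meta to a large group, gives a 1.5-fold lower number from compound 1 to compound 3 (0.17 log units; within the scatter) and so shows this position accepting a group of 4 heavy atoms in place of 1 without a change beyond the scatter. Within the data shown here, this is the first exchange at this position, and it leaves the number in the range of the earlier compounds. No supporting measurement bears on the reason for this outcome.

The compounds shown leave open whether an amine or a carboxylic acid at this position would shift the number beyond the scatter. They also leave open what a longer chain would do here.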